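Cyclohexene-fused aminonitrile sulfonamides: variation at the saturated ring carbon

The compounds below may be only part of what the source reports. "The series", "measured", "known", "first", "only" and "open" are said of these compounds alone.

Measured compounds:
compound 1 `N#CC1=C(N)N(c2ccc(S(N)(=O)=O)cc2)C2=C(CCCC2)C1c1ccccc1O` gives 100%
compound 2 `N#CC1=C(N)N(c2ccc(S(N)(=O)=O)cc2)C2=C(CCCC2)C1/C=C/c1ccccc1` gives 70%
compound 3 `N#CC1=C(N)N(c2ccc(S(N)(=O)=O)cc2)C2=C(CCCC2)C1c1ccc(Cl)cc1Cl` gives 70%

In a functional assay on Ehrlich cells (Mus musculus) for cytotoxicity, read by trypan blue exclusion, with a stated time of 2 h, tested at 100 ug/mL (a higher number here means a stronger effect of the compound at the concentration tested, a lower number a weaker effect), compound 2 sits level with compound 3 at the digits printed, the two together the lowest of the three numbers; compound 1 stands higher by a number 30 percentage points lower from compound 1 to compound 2 (beyond the scatter). The step of no change at the digits printed from compound 2 to compound 3 (within the scatter) shows that exchanging one group on the saturated ring carbon for another, neither being 2-hydroxyphenyl, leaves the read-out unmoved.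

Compound 4 `Cc1ccc(C2C(C#N)=C(N)N(c3ccc(S(N)(=O)=O)cc3)C3=C2CCCC3)o1` differs from compound 2 as follows: 5-methylfuran-2-yl in place of 2-phenylethenyl on a saturated ring carbon. The bearing steps are a number 30 percentage points lower from compound 1 to compound 2 (beyond the scatter) and a number 30 percentage points lower from compound 1 to compound 3 (beyond the scatter), both tied to loss of 2-hydroxyphenyl, and no change at the digits printed from compound 2 to compound 3 (within the scatter), within the scatter. Compound 4 also lacks 2-hydroxyphenyl, so the expected step is no change at the digits printed from compound 2 to compound 4 (within the scatter), no change beyond the scatter. Compound 4 is estimated at 70%, between 50% and 90%.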

Compound 4, a percentage reported as activity, at one concentration (the size of the read-out at that concentration, not a potency): 30%
Compound 4: the middle estimate sits 40 percentage points above what was measured, outside the stated range (below it).
By their numbers in this assay, from the lowest: compound 4; then compounds 2 and 3 (each within the scatter of the next); then compound 1.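

Not every replacement of 2-hydroxyphenyl on the saturated ring carbon behaves alike: the read-out shows a number 40 percentage points lower from compound 2 to compound 4 (beyond the scatter) and also a number 40 percentage points lower from compound 3 to compound 4 (beyond the scatter), so the tie between compound 2 and compound 3 does not extend to 5-methylfuran-2-yl. The span at this position is now wider, with a number 70 percentage points lower from compound 1 to compound 4 (beyond the scatter) as the largest step in the set. Nothing available accounts for this drop.

On these data alone, whether the drop follows the furan itself or its methyl group remains open. Also open, as far as these compounds go, is where an unsubstituted furan-2-yl, a thiophene or a 4-aminophenyl would fall.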